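Swapping tert-butyl for cyclohexylmethyl on the most potent compound

The source may hold more compounds than are shown below. What is called first, only, known or untested is meant among the compounds shown, and "the series" means these compounds.

Measured in a functional assay on A2780 cells (Homo sapiens) for cytotoxicity; on this read-out higher numbers stand for weaker inhibition and lower numbers for stronger inhibition:
- compound 1 `CCc1cnc(CSc2cnc(NC(C)=O)s2)o1`: 1400 nM
- compound 2 `CC(=O)Nc1ncc(SCc2ncc(C(C)C)o2)s1`: 200 nM
- compound 3 `CC(=O)Nc1ncc(SCc2ncc(C(C)(C)C)o2)s1`: 50 nM

Compound 3 has the lowest number of the three at 50 nM, which makes it the most potent so far. The next candidate, compound 4 `CC(=O)Nc1ncc(SCc2ncc(CC3CCCCC3)o2)s1`, keeps the shared core and has cyclohexylmethyl in place of tert-butyl on an aromatic carbon.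

All three measured steps concern this same group. One added methyl gave a 7.0-fold lower number from compound 1 to compound 2 (0.85 log units; beyond the scatter), and a second gave a 4.0-fold lower number from compound 2 to compound 3 (0.60 log units; beyond the scatter). Taken whole, tert-butyl in place of ethyl gave a 28-fold lower number from compound 1 to compound 3 (1.45 log units; beyond the scatter). Each step lies beyond the scatter, so across these three compounds the number fell as methyl groups were added. Cyclohexylmethyl lacks that branching at the carbon bound to the aromatic carbon, which resembles the ethyl of compound 1 at 1400 nM. Among the measured compounds shown here, no measured compound carries a ring there, so this comparison is loose.

A modest rise in the number is expected in this assay, a 6.0-fold higher number from compound 3 to compound 4 (0.78 log units; beyond the scatter). The estimated value for compound 4 is 300 nM. The expected range for compound 4 runs from 70 nM to 1300 nM.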

Compound 4, half-maximal inhibitory concentration: 1540 nM
For compound 4 the middle estimate is 5.1-fold (0.71 log units) below the measured one; measured number outside the range, above it.
By their numbers in this assay, from the lowest: compound 3; then compound 2; then compounds 1 and 4 (each within the scatter of the next).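

In this assay, a larger group at this position does not by itself bring a lower number: cyclohexylmethyl carries more heavy atoms than tert-butyl and isopropyl, yet it gives a higher number than tert-butyl (a 31-fold higher number from compound 3 to compound 4 (1.49 log units; beyond the scatter)) and than isopropyl (a 7.7-fold higher number from compound 2 to compound 4 (0.89 log units; beyond the scatter)). Against compound 1, which has ethyl here, the cyclohexyl ring in place of the chain-end methyl changes nothing that can be told apart (a 1.1-fold higher number from compound 1 to compound 4 (0.04 log units; within the scatter)), so the low numbers of this short series are not reached by adding carbon alone. Nothing available explains this result.

The change brings in a ring and removes the branching at the carbon bound to the aromatic carbon, and these two features remain unseparated. A cyclohexyl group bound directly to that aromatic carbon would keep the ring while restoring branching there.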